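The source may hold more compounds than are shown below. What is called first, only, known or untested is meant among the compounds shown, and "the series" means these compounds.

In an ADME assay on liver for metabolic stability, with Liver microsome (Homo sapiens) as the target, read by LC-MS, using microsomes (a higher number here means faster removal of the compound, a lower number slower removal), two compounds have been measured:

- compound 1 `CC(C)CC[C@@H](O)C(=O)N1N=CC[C@H]1C(=O)NCc1cc(Cl)ccc1-n1cnnn1` gives 47 mL.min-1.g-1 as a number
- compound 2 `CC(C)(C)[C@@H](O)C(=O)N1N=CC[C@H]1C(=O)NCc1cc(Cl)ccc1-n1cnnn1` gives < 12 mL.min-1.g-1 as a limit

For compound 2 the reading < 12 mL.min-1.g-1 is a limit of the assay and not a number. Its standing is given by the limit of < 12 mL.min-1.g-1 in this assay, at which 1 of the 2 values shown sits, and no exact value is known for it.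

The next compound is compound 3 `CCCC[C@@H](O)C(=O)N1N=CC[C@H]1C(=O)NCc1cc(Cl)ccc1-n1cnnn1` which keeps the shared core. It carries butyl in place of tert-butyl on a saturated chain carbon bound to a carbonyl carbon and an oxygen on a saturated carbon. The change comes to butyl in place of tert-butyl on a saturated chain carbon bound to a carbonyl carbon and an oxygen on a saturated carbon and the two compounds have the same atoms, joined differently.

Within the data shown here, one measured step bears on this. It is an at least 3.9-fold lower number from compound 1 to compound 2 (0.59 log units; beyond the scatter) and it came with tert-butyl replacing isopentyl at the same place. Taking tert-butyl away again might undo much of that step, so a higher number beyond the scatter is expected in this assay for the new chain. That expectation amounts to an at least 2.5-fold higher number from compound 2 to compound 3 (0.39 log units; beyond the scatter) as an estimated step. Compound 3 is estimated to give 30 mL.min-1.g-1 in this measurement (14 mL.min-1.g-1 to 60 mL.min-1.g-1).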

Compound 3, intrinsic clearance in microsomes: < 12 mL.min-1.g-1
Compound 3 gave a limit, no number; the forecaster's own chance of this, stated with the estimate: 10%; middle value at least 2.5-fold (0.39 log units) from the limit.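

In this assay compound 3 reads < 12 mL.min-1.g-1, which is a limit of the assay and not a number. This shows that a low reading at this position does not depend on tert-butyl, since the unbranched butyl chain, built from the same atoms, also gives one; taking away a single methyl from the isopentyl chain, with hydrogen in place of methyl on a saturated chain carbon bound to two saturated chain carbons, already gives an at least 3.9-fold lower number from compound 1 to compound 3 (0.59 log units; beyond the scatter). Compound 2 and compound 3 now stand at the same limit, so the step between them cannot be read and neither can be ranked above the other: the limit of < 12 mL.min-1.g-1 in this assay, at which 2 of the 3 values shown sit.

On these data alone, the true values of compound 2 and compound 3 remain unknown, so it stays open whether butyl and tert-butyl really match here or only share the limit. Also open, as far as these compounds go, is whether a shorter chain such as propyl, a longer chain such as pentyl, or an amine or a carboxylic acid at this place would stay at the limit or move the reading back up towards that of compound 1.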